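This account rests on a few compounds, and the source may have more. Where it says the series, first, only, none or still open, it means among the compounds named here.

In an ADME assay on BJ cells (Homo sapiens) for antiproliferative activity, with a stated time of 72 h (on this read-out higher numbers stand for an effect only at larger amounts of compound and lower numbers for an effect already at smaller amounts), three compounds have been measured: compound 1 `COc1ccc(-c2c(Cl)c(=O)c3c(OC)cc(OC)cc3n2S(=O)(=O)c2ccc(OC)cc2)cc1`, compound 2 `COc1ccc(-c2c(Br)c(=O)c3c(OC)cc(OC)cc3n2S(=O)(=O)c2ccc(OC)cc2)cc1` and compound 3 `COc1ccc(-c2cc(=O)c3c(OC)cc(OC)cc3n2S(=O)(=O)c2ccc(C)c([N+](=O)[O-])c2)cc1`. Compound 1 gives 90000 nM in this assay. Compound 2 gives 49700 nM. Among the compounds with values here, the only step between measured compounds is a 1.8-fold lower number from compound 1 to compound 2 (0.26 log units; within the scatter). Compound 3 reaches only a limit of the assay, > 51700 nM (the limit of > 51700 nM in this assay, at which 1 of the 3 values shown sits). Compound 4 `COc1ccc(-c2cc(=O)c3c(OC)cc(OC)cc3n2S(=O)(=O)c2cc(Cl)cc(Cl)c2O)cc1` differs from compound 3 at the sulfonyl group: 3,5-dichloro-2-hydroxyphenyl in place of 4-methyl-3-nitrophenyl on a sulfonyl sulfur. Within the data shown here, no measured step touches this part of the molecule, and the step from compound 1 to compound 2 serves only as a gauge of the scatter. The step that the limit leaves unreadable from compound 3 to compound 4 is therefore expected to be small. Compound 4 is estimated at 60000 nM in this assay, with a range from 20000 nM to 200000 nM.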

Compound 4, half-maximal effective concentration: > 37900 nM
Compound 4: no number, only a limit; the forecaster's own chance of this, stated with the estimate: 50%; the middle value is on the limit's open side.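

Within the data shown here, compound 3 and compound 4 both reach only limits of the assay, so no step between them can be read. The compounds shown leave open whether 3,5-dichloro-2-hydroxyphenyl in place of 4-methyl-3-nitrophenyl on a sulfonyl sulfur changes the result in this assay.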